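Benzofuran in place of the bicyclic azole at the amide

The compounds below may be only part of what the source reports. "The series", "measured", "known", "first", "only" and "open" are said of these compounds alone.

In an ADME assay on MRC5 cells (Homo sapiens) for inhibition, with a stated time of 72 h (a higher number here means that more compound is needed for the effect, a lower number that less compound is needed), compound 3 `CO[C@H]1CC[C@H](NC(=O)c2n[nH]cc2NC(=O)c2cc3ccccn3n2)CC1` gives 1000 nM, the second highest of three numbers: compound 1 `CO[C@H]1CC[C@H](NC(=O)c2n[nH]cc2NC(=O)c2ccc(F)cc2F)CC1` gives 11000 nM and compound 2 `CO[C@H]1CC[C@H](NC(=O)c2n[nH]cc2NC(=O)c2ccc(-c3ccccc3)o2)CC1` gives 100 nM. Compound 4 `CO[C@H]1CC[C@H](NC(=O)c2n[nH]cc2NC(=O)c2cc3ccccc3o2)CC1` differs from compound 3 at the carbonyl carbon by a group of 9 heavy atoms (8 carbon, 1 oxygen; one five-membered aromatic ring with 1 hetero atom, one six-membered aromatic ring of carbon only) in place of a group of 9 heavy atoms (7 carbon, 2 nitrogen; one five-membered aromatic ring with 2 hetero atoms, one six-membered aromatic ring with 1 hetero atom), on a carbonyl carbon. Among the compounds with values here, the only measured step at this position is an 11-fold lower number from compound 1 to compound 3 (1.04 log units; beyond the scatter), a large change, so the group on that carbonyl carbon matters much in this assay. Compound 2, which carries an oxygen-containing five-membered aromatic ring at the same place, shows a lower number than compound 3. For compound 4 a lower number than compound 3 is therefore expected, by about a 3.3-fold lower number from compound 3 to compound 4 (0.52 log units; beyond the scatter), with an estimate of 300 nM and a range from 100 nM to 1500 nM.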

Compound 4, half-maximal effective concentration: 800 nM
For compound 4 the middle estimate is 2.7-fold (0.43 log units) below the measured one; low and high end bracket the measured number.
By their numbers in this assay, from the lowest: compound 2; then compounds 4 and 3 (each within the scatter of the next); then compound 1.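

In this assay, exchanging the bicyclic group on the carbonyl carbon for 1-benzofuran-2-yl makes no clear difference (a 1.3-fold lower number from compound 3 to compound 4 (0.10 log units; within the scatter)), so the two nitrogens of the leaving group can give way to the single oxygen of the entering one. Against 2,4-difluorophenyl, 1-benzofuran-2-yl gives a large step (a 14-fold lower number from compound 1 to compound 4 (1.14 log units; beyond the scatter)), so compound 3 and compound 4 both stand well clear of compound 1. No measured evidence accounts for this result. Still open, from the compounds shown here alone, is how an amine or a carboxylic acid on the 1-benzofuran-2-yl group would shift the number.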